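Replacing an Aryl Group While Cytotoxicity Stays Below Detection

This account rests on a few compounds, and the source may have more. Where it says the series, first, only, none or still open, it means among the compounds named here.

Compound 1, `O=c1n(Cc2cc3ccncc3n2CCCCO)c2cnccc2n1C1CC1`, gives > 100000 nM in an ADME assay on HeLa cells (Homo sapiens) for cytotoxicity, read by ATP content, with a stated time of 3 days; on this read-out higher numbers stand for lower toxicity in this test and lower numbers for higher toxicity in this test; this is a limit of the test, not a number.
Compound 2, `CC(C)CCn1c(Cn2c(=O)n(C3CC3)c3ccncc32)nc2nc(Cl)ccc21`, gives > 50000 nM in this assay; this too is a limit.
Compound 3, `COc1ccc(-n2c(=O)n(Cc3cc4cc(Cl)ccc4n3CCCC#N)c3cnccc32)cc1OC`, gives > 50000 nM in this assay; again a limit.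

So compound 3 stands where two of the three measured compounds stand, at the limit of > 50000 nM in this assay, at which 2 of the 3 values shown sit, and none of the three shows measurable toxicity. Compound 4, `N#CCCCn1c(Cn2c(=O)n(-c3ncco3)c3ccncc32)cc2cc(Cl)ccc21`, differs from compound 3 by 1,3-oxazol-2-yl in place of 3,4-dimethoxyphenyl on an aromatic nitrogen. Among the measured compounds shown here, no measured pair shows the effect of such a change here. The expectation is that the step from compound 3 to compound 4 stays within the usual scatter, a step that the limit leaves unreadable from compound 3 to compound 4, most likely again ending in a limit. Compound 4 is therefore estimated at 70000 nM, with a range from 30000 nM to 150000 nM.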

Compound 4, half-maximal cytotoxic concentration: > 50000 nM
Compound 4: a limit, no number; the forecaster's own chance of this, stated with the estimate: 85%; the middle value does not contradict the limit.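

Compound 3 and compound 4 both end in a limit rather than a number, so the step between them cannot be read. The compounds shown leave open whether 1,3-oxazol-2-yl in place of 3,4-dimethoxyphenyl changes toxicity at all in this assay.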